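The source may hold more compounds than are shown below. What is called first, only, known or untested is meant among the compounds shown, and "the series" means these compounds.

In a functional assay on MCF7 cells (Homo sapiens) for antiproliferative activity, read by MTT assay, with a stated time of 48 h (a lower number here means a stronger inhibitor, a higher number a weaker inhibitor), compound 3 `COC(=O)CN(C)c1nc(Nc2ccc(Cl)cc2)ncc1[N+](=O)[O-]` gives 60700 nM. Within the data shown here, this is the highest of the two numbers known here, though the nearest, compound 2 `CCOC(=O)CN(Cc1ccccc1)c1nc(NCc2cccc(OC)c2)ncc1[N+](=O)[O-]` with 57400 nM, sits within the usual scatter of it, so no order can be read between them. For compound 1 `CCOC(=O)CN(Cc1ccccc1)c1nc(NCc2ccccc2)ncc1[N+](=O)[O-]` the assay reports only a limit, > 100000 nM (the limit of > 100000 nM in this assay, at which 1 of the 3 values shown sits). Among the measured compounds shown here, the one measured step, an at least 1.7-fold lower number from compound 1 to compound 2 (0.24 log units; that floor lies within the scatter), concerns a methoxy group on the other side of the shared core and does not touch the amine in question. Compound 4 `COC(=O)CN(C)c1nc(NCc2ccccc2)ncc1[N+](=O)[O-]` differs from compound 3 by benzyl in place of 4-chlorophenyl on a nitrogen on an aromatic ring. For the measured compounds named here, no measured step bears on this change, so the expectation is a step of a 1.0-fold lower number from compound 3 to compound 4 (0.01 log units; within the scatter) that stays within the scatter. Compound 4 is therefore estimated at 60000 nM, with a range from 20000 nM to 180000 nM.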

Compound 4, half-maximal inhibitory concentration: 85900 nM
Beside the measured number, compound 4's estimate is 1.4-fold (0.16 log units) below it, and the stated range covers the measured number.
By their numbers in this assay, from the lowest: compounds 2, 3 and 4 (each within the scatter of the next). At a limit, above all of these: compound 1.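

On the nitrogen on an aromatic ring, benzyl in place of 4-chlorophenyl gives a 1.4-fold higher number from compound 3 to compound 4 (0.15 log units; within the scatter) in this assay. Among these compounds, this is the first measured step at this amine, and it shows that this exchange of groups does not separate the two compounds beyond the scatter. Nothing measured here gives a reason for the size of this step. The exchange removes the chlorine and alters the link to the ring at once, so 4-chlorobenzyl on this nitrogen would be needed to tell those two parts apart. From the compounds shown here alone, whether a longer chain here would shift the number remains open.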